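Swapping the fluorophenyl amide for a chlorophenyl amide

A few compounds are considered here, and "the series" means these few. Any claim that something is new, unique, unknown or untested is made for them only; others in the source may bear on it.

Of the compounds shown here, two sharing one core have been measured in an assay on isolated protein with metabotropic glutamate receptor 5 (Rattus norvegicus) as the target; a higher number here means that more compound is needed for the effect, a lower number that less compound is needed. Compound 1 `O=C(Nc1cc(-c2ccccc2)nn1-c1ccccc1)c1ccc(F)c(F)c1` gives 20 nM, and compound 2 `O=C(Nc1cc(-c2ccccc2)nn1-c1ccccc1)c1ccc(F)cc1` gives 50 nM. Among the compounds with values here, the single measured step, a 2.5-fold higher number from compound 1 to compound 2 (0.40 log units; beyond the scatter), removes one fluoro from the ring attached to the carbonyl. Among the two numbers, compound 2 stands highest, needing the most compound, with compound 1 as its only neighbour.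

Compound 3 `O=C(Nc1cc(-c2ccccc2)nn1-c1ccccc1)c1cccc(Cl)c1` changes that same ring in another way: 3-chlorophenyl in place of 4-fluorophenyl on a carbonyl carbon. Within the data shown here, no measured step mirrors this change, and the step from compound 1 to compound 2 only shows that a single fluoro on this ring shifts the number modestly. Among the measured compounds shown here, with no direct precedent, the expected step is no change at the digits printed from compound 2 to compound 3 (within the scatter), meaning little change beyond the scatter. Compound 3 is therefore estimated at 50 nM, with a plausible range from 15 nM to 200 nM.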

Compound 3, half-maximal effective concentration: 200 nM
Estimate against measurement, compound 3: 4.0-fold (0.60 log units) below; measured number inside the range.
By their numbers in this assay, from the lowest: compound 1; then compound 2; then compound 3.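

This position responds to more than the number of halogens on the ring: compound 2 and compound 3 each carry just one, yet 3-chlorophenyl in place of 4-fluorophenyl gives a 4.0-fold higher number from compound 2 to compound 3 (0.60 log units; beyond the scatter). Set against the 3,4-difluorophenyl group, the same 3-chlorophenyl group gives a 10-fold higher number from compound 1 to compound 3 (1.00 log units; beyond the scatter), so the three compounds now spread over a clear range through changes to this one ring alone. Nothing available explains why the number rises with this change.

Since the halogen changes both its identity and its place from compound 2 to compound 3, these compounds cannot show which of the two matters, and a ring with fluoro where compound 3 has chlorine, or chlorine where compound 2 has fluoro, would separate them. From the compounds shown here alone, how a methyl or a nitrile on this ring would fare also remains open.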